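A few compounds are considered here, and "the series" means these few. Any claim that something is new, unique, unknown or untested is made for them only; others in the source may bear on it.

Measured so far in a functional assay on XF498 cells (Homo sapiens) for antiproliferative activity, read by MTT assay, with a stated time of 96 h; a lower number here means a stronger inhibitor, a higher number a weaker inhibitor:
compound 1 `O=C1NNC(=O)C2(CSC3=C2C(=O)c2ncccc2C3=O)N1` — 5000 nM
compound 2 `O=C1NC(=O)C2(CSC3=C2C(=O)c2ncccc2C3=O)N1` — 3120 nM
compound 3 `O=C1NN(c2ccc(Cl)cc2)C(=O)C2(CSC3=C2C(=O)c2ncccc2C3=O)N1` — 2500 nM

Compound 2 stands second highest of the three numbers; its nearest neighbour is compound 3, a little lower, and the furthest is compound 1, a little higher, both gaps within the scatter. The three numbers therefore sit in one band.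

Compound 4 `CCCCc1ccc(N2C(=O)NC3(CSC4=C3C(=O)c3ncccc3C4=O)C2=O)cc1` is not yet measured. It differs from compound 2 as follows: 4-butylphenyl in place of hydrogen on an amide-type nitrogen in a ring

Within the data shown here, the one measured step that bears on this is the move from compound 1 to compound 3, an aryl group in place of hydrogen on an amide-type nitrogen in a ring, which gave a 2.0-fold lower number from compound 1 to compound 3 (0.30 log units; within the scatter). That step is within the scatter, so the analogous change on compound 2 is expected to give at most a small downward step, a 1.6-fold lower number from compound 2 to compound 4 (0.19 log units; within the scatter), and possibly none beyond the scatter. Among the measured compounds shown here, no measured compound carries a 4-butylphenyl, so the size of the butyl chain adds uncertainty.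

Compound 4 is estimated at 2000 nM, with a range from 800 nM to 5000 nM.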

Compound 4, half-maximal inhibitory concentration: 950 nM
Compound 4: middle estimate off by 2.1-fold (0.32 log units), on the high side, and the stated range covers the measured number.
By their numbers in this assay, from the lowest: compound 4; then compounds 3, 2 and 1 (each within the scatter of the next).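

In this assay, putting 4-butylphenyl in place of hydrogen on the amide-type nitrogen gives a 3.3-fold lower number from compound 2 to compound 4 (0.52 log units; beyond the scatter), so this position on the five-membered ring of compound 2 tolerates a large aryl substituent and responds to it beyond the scatter. The earlier aryl step on a different ring (a 2.0-fold lower number from compound 1 to compound 3 (0.30 log units; within the scatter)) stayed within the scatter and could not show this. No supporting data bear on why the number falls at this nitrogen.

The compounds shown do not separate the contribution of the phenyl ring from that of the butyl chain, and a plain phenyl at this nitrogen would address that. Also open, on these data alone, is whether a hexyl chain, or an amine or a carboxylic acid in place of the butyl, would extend or reverse the step.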